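The source may hold more compounds than are shown below. What is called first, only, known or untested is meant among the compounds shown, and "the series" means these compounds.

In a functional assay on HeLa cells (Homo sapiens) for antiproliferative activity, read by MTT assay, with a stated time of 48 h (on this read-out lower numbers stand for stronger inhibition and higher numbers for weaker inhibition), compound 1, `CCCCCCCCCCCCNc1nc2ccccc2nc1Oc1ccc(C(=O)N[C@H](C(=O)OC)[C@H](C)CC)cc1`, gives 40300 nM. Compound 2, `COC(=O)CNC(=O)c1ccc(Oc2nc3ccccc3nc2NC(C)(C)C)cc1`, gives > 50000 nM, which is a limit of the assay and not a number. Within the data shown here, that is the limit of > 50000 nM in this assay, at which 1 of the 2 values shown sits, so compound 2 has no exact place on the scale, and no step between measured compounds can be read from these two results.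

Compound 3, `C[C@H](NC(=O)c1ccc(Oc2nc3ccccc3nc2NC(C)(C)C)cc1)C(=O)O`, has the same atoms as compound 2, joined differently, with 1-carboxyethyl in place of (methoxycarbonyl)methyl on an amide-type nitrogen. Among the measured compounds shown here, no measured step shows what this exchange does in this assay.

The expectation therefore rests on compound 2, with its reading of > 50000 nM, and on the close match in counted atoms between the two groups. The expected change, a step that the limit leaves unreadable from compound 2 to compound 3, is estimated to stay within the usual scatter, with no clear direction. A reading for compound 3 that again reaches only the limit of the assay would not be surprising. For compound 3 the estimated half-maximal inhibitory concentration is 60000 nM, within an expected range of 25000 nM to 150000 nM.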

Compound 3, half-maximal inhibitory concentration: 23400 nM
Estimate against measurement, compound 3: 2.6-fold (0.41 log units) above; the whole stated range lies above it.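

In this assay, among these compounds, placing 1-carboxyethyl instead of (methoxycarbonyl)methyl on the amide-type nitrogen gives an at least 2.1-fold lower number from compound 2 to compound 3 (0.32 log units; beyond the scatter), the first change at this position whose direction can be read. The two groups are made of the same atoms, so this position responds to how those atoms are joined, not only to which atoms are present: the entering group carries a hydrogen-bond donor and a defined stereocentre, and the leaving group has neither. The step is a bound and not an exact size, because compound 2 stands at a limit of the assay and not at a number: the limit of > 50000 nM in this assay, at which 1 of the 3 values shown sits.

The compounds shown do not separate the two things that change together here, the methyl ester giving way to a carboxylic acid and the extra methyl branch appearing on the chain. A carboxymethyl group or a 1-(methoxycarbonyl)ethyl group on the same nitrogen would pull these two apart, and the opposite configuration of the 1-carboxyethyl group would show whether the stereocentre matters.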